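Vero cell tolerance across a small methoxy-varied series

This account rests on a few compounds, and the source may have more. Where it says the series, first, only, none or still open, it means among the compounds named here.

Measured compounds:
- Compound 1 `COc1cccc(/C=C2\CCC/C(=C\c3ccc([N+](=O)[O-])cc3)C2=O)c1OC`: in an ADME assay on Vero cells (Chlorocebus sabaeus) for inhibition (a higher number here means that more compound is tolerated, a lower number that less compound is tolerated), compound 1 gives < 10000 nM, which is a limit of the assay and not a number.
- Compound 2 `COc1cccc(/C=C2\CCC/C(=C\c3cc(OC)c(OC)c(OC)c3)C2=O)c1OC`: in this assay compound 2 gives 29300 nM.
- Compound 3 `COc1cc([N+](=O)[O-])ccc1/C=C1\CCC/C(=C\c2cccc(OC)c2OC)C1=O`: in this assay compound 3 gives 120000 nM.

Compound 3 sits highest of the two numbers, compound 2 lowest, and the gap between them is beyond the scatter. The difference between the two cores of compound 2 and compound 3 is not broken down here.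

One change is made on a measured pair: hydrogen in place of methoxy on an aromatic carbon. It gives an at least 12-fold lower number from compound 3 to compound 1 (1.07 log units; beyond the scatter), a large drop in tolerated concentration, with compound 1 reported only at the limit of < 10000 nM in this assay, at which 1 of the 3 values shown sits.

Compound 4 `COc1ccc(/C=C2\CCC/C(=C\c3cccc(OC)c3OC)C2=O)cc1OC` is not yet measured. It differs from compound 2 by hydrogen in place of methoxy on an aromatic carbon. This is the same kind of change as from compound 3 to compound 1, but not the same: there the leaving methoxy sat ortho to a large group and meta to a nitro group, here it sits ortho to a methoxy group, meta to a large group and meta to a methoxy group. For the measured compounds named here, only the one measured step is available as a guide, and its surroundings differ, so the expectation carries wide bounds. A drop is expected for compound 4, estimated as a 2.9-fold lower number from compound 2 to compound 4 (0.47 log units; beyond the scatter), resting on the step seen from compound 3 to compound 1 an at least 12-fold lower number from compound 3 to compound 1 (1.07 log units; beyond the scatter), which points the same way, moderated for the differing place. Compound 4 is thus expected to give about 10000 nM in this assay, between 3000 nM and 35000 nM, with a fair chance that only a limit is reported.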

Compound 4, half-maximal cytotoxic concentration: 36100 nM
Estimate against measurement, compound 4: 3.6-fold (0.56 log units) below; measured number outside the range, above it.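

In this assay, hydrogen in place of methoxy on an aromatic carbon gives a 1.2-fold higher number from compound 2 to compound 4 (0.09 log units; within the scatter), and this result does not repeat the large drop seen on the other core: the same change on two cores in this assay, an at least 12-fold lower number (1.07 log units; beyond the scatter) from compound 3 to compound 1 and a 1.2-fold higher number (0.09 log units; within the scatter) from compound 2 to compound 4, at least 14-fold (1.16 log units) apart, beyond the scatter of two such steps

Compound 1 is reported only as a limit of the assay and not a number, so the full size of the earlier step stays unknown: the limit of < 10000 nM in this assay, at which 1 of the 4 values shown sits.

For the compounds shown here, the two steps show that this change cannot be carried from one core to another at a fixed size, but they do not show which difference between the two cores sets them apart, and a comparison of only two cores gives no rule for a further one.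

The aromatic groups shown are limited to methoxy and nitro, so it remains open how an amine or a carboxylic acid in the place of the nitro group would read in this assay. Also open, from the compounds shown here alone, is whether the same replacement of methoxy by hydrogen at other places on these rings would follow the step on compound 2 or the step on compound 3.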